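The source may report more compounds than this note shows. Statements on the series, on what has been measured and on what is new or still open speak of the compounds shown alone.

Of the compounds shown here, three have been measured in a functional assay on VCaP cells (Homo sapiens) for antiproliferative activity, read by CCK-8 assay, with a stated time of 6 days; on this read-out lower numbers stand for stronger inhibition and higher numbers for weaker inhibition. Compound 1 `CCN(c1ccc(C#N)c(Cl)c1)c1cc(-c2ccncc2)ccc1C` gives 2900 nM in this assay. Compound 3 `CCN(c1ccc(C#N)c(Cl)c1)c1cc(-c2cccnc2)ccc1C` carries pyridin-3-yl in place of pyridin-4-yl on an aromatic carbon, and in this assay compound 3 gives 1270 nM; the change brought a 2.3-fold lower number from compound 1 to compound 3 (0.36 log units; beyond the scatter). Compound 2 `N#Cc1ccc(N2CCc3cc(-c4ccncc4)ccc3C2)cc1C(F)(F)F` rests on another core, and the difference between the two cores is not broken down here. In this assay compound 2 gives 3500 nM, a number within the scatter of compound 1 and beyond the scatter from compound 3.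

Compound 4 `N#Cc1ccc(N2CCc3cc(-c4cccnc4)ccc3C2)cc1C(F)(F)F` has not yet been measured. It differs from compound 2 by pyridin-3-yl in place of pyridin-4-yl on an aromatic carbon. This is the same kind of change as that from compound 1 to compound 3, but not the same: there the place was on a six-membered aromatic ring of carbon only, meta to a large group and para to a methyl group, whereas in compound 4 the place is part of a fused or bridged system of two rings, meta to a fused ring and para to a fused ring. The change occurs in only two pairs among the compounds shown, so a single measured step is all there is to lean on. Because that step gave a 2.3-fold lower number from compound 1 to compound 3 (0.36 log units; beyond the scatter), compound 4 is expected to show a step of about a 2.2-fold lower number from compound 2 to compound 4 (0.34 log units; beyond the scatter) in this assay. Compound 4 is therefore estimated at 1600 nM, most likely between 700 nM and 3600 nM.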

Compound 4, half-maximal inhibitory concentration: 2530 nM
For compound 4 the middle estimate is 1.6-fold (0.20 log units) below the measured one; the measured number falls inside the stated range.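

On the core of compound 2, pyridin-3-yl in place of pyridin-4-yl gave a 1.4-fold lower number from compound 2 to compound 4 (0.14 log units; within the scatter) in this assay, so on this core the change alone cannot be told apart from the spread of repeated measurements. Set beside the step on the core of compound 1, the result gives no sign that the two cores respond differently to this change: the same change on two cores in this assay, a 2.3-fold lower number (0.36 log units; beyond the scatter) from compound 1 to compound 3 and a 1.4-fold lower number (0.14 log units; within the scatter) from compound 2 to compound 4, 1.7-fold (0.22 log units) apart, within the scatter of two such steps. Among these compounds, this makes the two steps compatible with a change that carries from one core to the other, but it does not show that the step is the same on both, that pyridin-3-yl brings a real gain on the core of compound 2, or that the same would hold on any further core, since only two pairs are at hand.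

The compounds shown carry only pyridin-3-yl or pyridin-4-yl at this place, so it remains open how pyridin-2-yl, a plain phenyl ring, or a pyridine bearing an amine or a carboxylic acid would read in this assay. The two cores also differ from each other in more than one place, and what each of those differences contributes to the numbers remains unresolved.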